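Methoxy to butoxy: a longer chain on the shared core

This account rests on a few compounds, and the source may have more. Where it says the series, first, only, none or still open, it means among the compounds named here.

Compound 1 `O=C(O)COc1ccc(OCc2ccc3ccccc3n2)cc1C1(c2ccccc2)CC2CCC1C2`: > 3000 nM
Compound 2 `CCOC(=O)CCCOc1ccc(OCc2ccc3ccccc3n2)cc1C1(c2ccccc2)CC2CCC1C2`: 150 nM
Compound 3 `COc1ccc(OCc2ccc3ccccc3n2)cc1C1(c2ccccc2)CC2CCC1C2`: 1100 nM

In a functional assay on blood (Homo sapiens) for inhibition (on this read-out higher numbers stand for weaker inhibition and lower numbers for stronger inhibition), compound 1 gives > 3000 nM, which is a limit of the assay and not a number. Compound 3, at 1100 nM, holds the higher of the two actual numbers. Compound 4 `CCCCOc1ccc(OCc2ccc3ccccc3n2)cc1C1(c2ccccc2)CC2CCC1C2` has propyl in place of hydrogen on a saturated chain carbon bound to an oxygen on an aromatic ring. The nearest guide is compound 2, which carries a longer chain at that place, and the measured step is a 7.3-fold higher number from compound 2 to compound 3 (0.87 log units; beyond the scatter). Carboxy there points the other way, with an at least 2.7-fold lower number from compound 1 to compound 3 (0.43 log units; beyond the scatter). Compound 4 lacks the ethoxycarbonyl of compound 2, so a modest drop is expected, a 3.1-fold lower number from compound 3 to compound 4 (0.50 log units; beyond the scatter). The estimate for compound 4 is 350 nM, within an expected range of 120 nM to 1100 nM.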

Compound 4, half-maximal inhibitory concentration: > 3000 nM
Compound 4: no number, only a limit; the forecaster's own chance of this, stated with the estimate: 3%; middle value at least 8.5-fold (0.93 log units) away from the limit.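

Lengthening methoxy to butoxy on the shared core weakens inhibition in this assay (an at least 2.7-fold higher number from compound 3 to compound 4 (0.43 log units; beyond the scatter)). Chain length alone therefore does not give the stronger inhibition of compound 2: ending the same chain in ethoxycarbonyl rather than methyl makes a large difference (an at least 20-fold higher number from compound 2 to compound 4 (1.30 log units; beyond the scatter)). Compound 4 gives only a limit of the assay, not a number, and the step from compound 1 to compound 4 cannot be read: the limit of > 3000 nM in this assay, at which 2 of the 4 values shown sit.

As far as these compounds go, whether an amine or a carboxylic acid at the end of the butoxy chain would match the ethoxycarbonyl of compound 2 stays open. So does the effect of an intermediate chain such as ethoxy.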